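A few compounds are considered here, and "the series" means these few. Any claim that something is new, unique, unknown or untested is made for them only; others in the source may bear on it.

Working notes on a series of dichlorophenyl-isoxazole carboxamides tested in a functional assay on the whole organism for inhibition, with Chenopodium ficifolium as the target, with a stated time of 72 h, tested at 100 mg/L; on this read-out lower numbers stand for less inhibition of growth and higher numbers for more inhibition of growth at the one concentration tested. Compound 1 `COc1cc(Cl)nc(NC(=S)NC(=O)c2c(-c3ccc(Cl)cc3Cl)noc2C)n1` gives 53.2%, the lowest of the three numbers recorded. Compound 2 `Cc1onc(-c2ccc(Cl)cc2Cl)c1C(=O)/N=c1/nc2nc(Cl)cc(C)n2s1` gives 73.6%, and compound 3 `COc1cc(OC)n2s/c(=N\C(=O)c3c(-c4ccc(Cl)cc4Cl)noc3C)nc2n1` gives 82.7%; both lie beyond the scatter above compound 1, with compound 3 furthest away. Among the measured compounds shown here, no pair among the measured compounds differs in a single place, so no measured step is available to anchor the next change.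

Compound 4 `Cc1cc(C)nc(NC(=S)NC(=O)c2c(-c3ccc(Cl)cc3Cl)noc2C)n1` is the unmeasured member; it differs from compound 1 in a single place: 4,6-dimethylpyrimidin-2-yl in place of 4-chloro-6-methoxypyrimidin-2-yl on an amide-type nitrogen. The thiourea linkage to the carboxamide is kept, and only the substitution pattern on the pyrimidinyl ring changes. With no measured step of this kind in the series, the expectation is a step from compound 1 to compound 4 of a number 3.2 percentage points lower from compound 1 to compound 4 (within the scatter), that is, no change beyond the scatter in either direction. Compound 4 is therefore expected to give about 50%, within a range of 30% to 72%.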

Compound 4, percent growth inhibition at one concentration: 65.4%
The estimate for compound 4 lay 15.4 percentage points below the measured number, and the stated range covers the measured number.
By their numbers in this assay, from the lowest: compound 1; then compounds 4, 2 and 3 (each within the scatter of the next, the first and the last beyond it).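

In this assay, among the compounds shown here, the open thiourea compounds now have a first measured step at the pyrimidinyl group on the amide-type nitrogen: 4,6-dimethylpyrimidin-2-yl in place of 4-chloro-6-methoxypyrimidin-2-yl gives a number 12.2 percentage points higher from compound 1 to compound 4 (beyond the scatter), so the number responds to a change at this position, if only modestly. Both the chloro and the methoxy substituent go in this one change, so the step cannot be divided between them. Nothing on hand bears on the reason for the step.

The compounds shown leave open whether 4-chloro-6-methylpyrimidin-2-yl or 4,6-dimethoxypyrimidin-2-yl on the same nitrogen would separate the two replacements. They also leave open how an amine or an ethyl group on the pyrimidinyl ring would read in this assay.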